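Carboxy on the Chain at the Ring Nitrogen

The compounds below may be only part of what the source reports. "The series", "measured", "known", "first", "only" and "open" are said of these compounds alone.

Two compounds of this series were tested for their effect on the growth of prostate cancer cells. Compound 1 `COc1cccc2cc(-c3ccccc3)c(O)nc12` in a functional assay on PC-3 cells (Homo sapiens) for cytotoxicity, read by colorimetric assay and MTT assay (on this read-out lower numbers stand for stronger inhibition and higher numbers for weaker inhibition), gives 10000 nM. Compound 2 `COc1ccc(-c2cc3c(OC)cc(OC)cc3n(C)c2=O)cc1`, which carries a methyl group on the aromatic nitrogen and two further methoxy groups on its core, gives in this assay a value of 10000 nM. Compound 2 thus stands level with compound 1 at the digits recorded, the two values lying within the usual scatter of the measurement, so no order between them can be claimed.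

Compound 3 `COc1ccc(-c2cc3c(OC)cc(OC)cc3n(CC(=O)O)c2=O)cc1` differs from compound 2 in one place only: carboxy in place of hydrogen on a saturated chain carbon bound to an aromatic nitrogen. Within the data shown here, no measured pair in this set shows what such a change does here. Given that compound 2 gives 10000 nM, the step of no change at the digits printed from compound 2 to compound 3 (within the scatter) is expected to be none beyond the scatter. For compound 3 in this assay a value of 10000 nM is estimated, with a range from 5000 nM to 20000 nM.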

Compound 3, half-maximal inhibitory concentration: 10000 nM
Estimate against measurement, compound 3: no gap at the digits printed; measured number inside the range.
By their numbers in this assay, from the lowest: compounds 1, 2 and 3 (each within the scatter of the next).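

In this assay, the step at this place, on a saturated chain carbon bound to an aromatic nitrogen, is now measured, and carboxy in place of hydrogen gives no change at the digits printed from compound 2 to compound 3 (within the scatter). Read one bond further out, this is methyl to carboxymethyl, so for this one pair on the shared core the chain carries carboxy with no change beyond the scatter. Nothing available here bears on why the number stays where it does.

As far as these compounds go, whether an amine, a methyl ester or a longer chain ending in carboxy at this place would give a different number remains open. With all three compounds level with one another, the compounds shown also offer no step beyond the scatter against which this change could be set.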